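Cyclobutyl for ethyl on the ring nitrogen of compound 3

This account rests on a few compounds, and the source may have more. Where it says the series, first, only, none or still open, it means among the compounds named here.

The series shares one core, carried with different groups on the aromatic nitrogen of the five-membered ring. Compound 3 `CCn1cnc2c(N(C)C)ncnc21` gives the lowest of the three numbers in a functional assay on the whole organism for antagonist activity, with Rattus norvegicus as the target (a higher number here means that more compound is needed for the effect, a lower number that less compound is needed), with 15 mg/kg. Compound 1 `CN(C)c1ncnc2c1ncn2Cc1cccc(N)c1` gives 23 mg/kg in this assay, a gap from compound 3 that stays within the scatter, so no order between those two can be read. Compound 2 `CN(C)c1ncnc2c1ncn2Cc1ccccc1F` gives 37 mg/kg in this assay, and that gap to compound 3 lies beyond the scatter. Among the measured compounds shown here, no two of the measured compounds differ in one place only, so no single step within the measured set can be followed.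

Compound 4 `CN(C)c1ncnc2c1ncn2C1CCC1` has not been measured. It differs from compound 3 as follows: cyclobutyl in place of ethyl on an aromatic nitrogen. For this assay only a small move is expected from this change, if any: the step from compound 3 to compound 4 is estimated as a 1.2-fold higher number from compound 3 to compound 4 (0.08 log units; within the scatter), which is not expected to exceed the scatter in either direction. On that basis compound 4 is expected to give about 18 mg/kg in this assay, with a range from 7 mg/kg to 45 mg/kg.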

Compound 4, dose for half-maximal effect: 11 mg/kg
Beside the measured number, compound 4's estimate is 1.6-fold (0.21 log units) above it, within the range that was stated.
By their numbers in this assay, from the lowest: compounds 4, 3, 1 and 2 (each within the scatter of the next, the first and the last beyond it).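

Cyclobutyl in place of ethyl on the aromatic nitrogen gives the first single-place comparison in the series: in this assay the step is a 1.4-fold lower number from compound 3 to compound 4 (0.13 log units; within the scatter) and stays within the scatter, so no order can be read between the two compounds. The position therefore accepts a group of 4 heavy atoms carrying a four-membered non-aromatic ring of carbon only, in place of the 2 heavy atoms of ethyl, with no change that can be told from the scatter in this whole-organism read-out. No measurement on these compounds offers an explanation for this result, so the finding remains an observation about this one pair.

What the compounds shown leave open is how far this acceptance extends at the same nitrogen: a larger carbon ring such as cyclohexyl, a longer chain such as n-hexyl, or a chain ending in a carboxylic acid or a primary amine could each give a step beyond the scatter or none at all. The pair also leaves open whether the same step from ethyl to cyclobutyl would hold if the rest of the shared core carried a different group.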